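The source may report more compounds than this note shows. Statements on the series, on what has been measured and on what is new or still open speak of the compounds shown alone.

Measured so far:
compound 1, `O=C1C=C(NCc2ccccc2)C(=O)c2c1nc1n2[C@H]2OC[C@@H](O)[C@H]2OC1`: > 8000 nM
compound 2, `O=C1C(Nc2ccc(Br)cc2)=CC(=O)c2c1nc1n2[C@H]2OC[C@@H](O)[C@H]2OC1`: 4330 nM
compound 3, `COc1ccc(NC2=CC(=O)c3nc4n(c3C2=O)[C@H]2OC[C@@H](O)[C@H]2OC4)cc1`: 5420 nM

In a functional assay on MCF7 cells (Homo sapiens) for inhibition, read by sulforhodamine B assay (a lower number here means a stronger inhibitor, a higher number a weaker inhibitor), compound 2 gives 4330 nM, the lowest of the two numbers available. Compound 3 gives 5420 nM, and the gap between compound 2 and compound 3 lies within the scatter. Compound 1 gives > 8000 nM, which is a limit of the assay and not a number (the limit of > 8000 nM in this assay, at which 1 of the 3 values shown sits). Among the compounds with values here, the one step with both ends measured, an at least 1.4-fold lower number from compound 1 to compound 3 (0.16 log units; that floor lies within the scatter), swaps 4-methoxyphenyl for benzyl on the amine nitrogen, and its floor lies within the scatter.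

Compound 4, `O=C1C(NC2CCCCC2)=CC(=O)c2c1nc1n2[C@H]2OC[C@@H](O)[C@H]2OC1`, is not yet measured. It differs from compound 2 in one place: cyclohexyl in place of 4-bromophenyl on an amine nitrogen. Within the data shown here, no measured step exchanges an aromatic ring for a saturated one on that nitrogen, so the only guidance is indirect. Compound 1, whose nitrogen carries a non-aromatic benzyl rather than an aryl group, sits at the limit, while compound 2 and compound 3, each with an aryl group there, give numbers. On that basis compound 4 is expected to give a higher number than compound 2, with an expected step of a 2.1-fold higher number from compound 2 to compound 4 (0.32 log units; beyond the scatter). The estimate for compound 4 in this assay is 9000 nM, expected to fall between 3000 nM and 30000 nM, with a fair chance that only a limit is reported.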

Compound 4, half-maximal inhibitory concentration: > 16000 nM
Compound 4 ended at the assay's limit (the forecaster's own chance of this, stated with the estimate: 50%); at least 1.7-fold (0.24 log units) between middle value and limit.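

In this assay compound 4 gives > 16000 nM, and this reading is a limit of the assay and not a number: the limit of > 16000 nM in this assay, at which 1 of the 4 values shown sits. Within the data shown here, the exchange of 4-bromophenyl for cyclohexyl on the amine nitrogen gives an at least 3.6-fold higher number from compound 2 to compound 4 (0.56 log units; beyond the scatter), so this change of group on the nitrogen moves the read-out beyond the scatter, which the one earlier step, an at least 1.4-fold lower number from compound 1 to compound 3 (0.16 log units; that floor lies within the scatter), could not establish. Both rings are six-membered and made of carbon only, and neither brings a hydrogen-bond donor or acceptor, so what changes here is that an aromatic ring carrying bromine gives way to a non-aromatic ring without it, and that change alone costs activity in this series.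

The compounds shown leave open whether the weaker result follows the loss of the aromatic ring or the loss of the bromine, a question that a plain phenyl on the same nitrogen would separate. They also leave open how far the true value of compound 4 lies past its limit, and whether a cyclohexyl ring carrying an amine or a carboxylic acid would behave in the same way.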